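The compounds below may be only part of what the source reports. "The series", "measured", "known", "first", "only" and "open" are said of these compounds alone.

Series notes. Compound 1 `Cc1cc2ccccc2nc1-c1cn(CCC(F)(F)C(F)(F)C(F)(F)C(F)(F)C(F)(F)C(F)(F)C(F)(F)C(F)(F)F)nn1`, compound 2 `CCCCCCCCCCn1cc(-c2nc3ccccc3cc2CCC)nn1` and compound 3 `CCCCCc1cc2ccccc2nc1-c1cn(CCC(F)(F)C(F)(F)C(F)(F)C(F)(F)C(F)(F)C(F)(F)C(F)(F)C(F)(F)F)nn1` share one core. In a functional assay on THP-1 cells (Homo sapiens) for cytotoxicity, read by MTT assay, with a stated time of 24 h (on this read-out lower numbers stand for stronger inhibition and higher numbers for weaker inhibition), compound 1 gives > 100 ug/mL, a limit of the assay. In this assay compound 2 gives > 100 ug/mL, also a limit. In this assay compound 3 gives > 100 ug/mL, again a limit, so compound 3 stands at the limit of > 100 ug/mL in this assay, at which 3 of the 3 values shown sit. The step that the two limits leave unreadable from compound 1 to compound 3 accordingly has no readable size. Compound 4 `CCCc1cc2ccccc2nc1-c1cn(CCC(F)(F)C(F)(F)C(F)(F)C(F)(F)C(F)(F)C(F)(F)C(F)(F)C(F)(F)F)nn1` differs from compound 3 by hydrogen in place of ethyl on a saturated chain carbon, three bonds along the chain from an aromatic carbon. For the measured compounds named here, only the step from compound 1 to compound 3 bears on this change, and it gives no size; with every value at the limit, no step beyond the scatter is expected in this assay. For compound 4 the estimate is 150 ug/mL, in the range 100 ug/mL to 400 ug/mL, the expected step being a step that the limit leaves unreadable from compound 3 to compound 4.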

Compound 4, half-maximal inhibitory concentration: > 100 ug/mL
Compound 4: a limit, no number; the forecaster's own chance of this, stated with the estimate: 85%; the middle value does not contradict the limit.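

In this assay compound 4 gives > 100 ug/mL, a limit. The steps from compound 1 and compound 3 to compound 4 therefore cannot be read. The compounds shown leave open what size, if any, these chain changes have: the limit of > 100 ug/mL in this assay, at which 4 of the 4 values shown sit.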